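Phenyl for Cyclopropyl on the Ring Amide Nitrogen

The source may report more compounds than this note shows. Statements on the series, on what has been measured and on what is new or still open speak of the compounds shown alone.

Compound 2 `O=C1COc2ccc(-c3cccc(NS(=O)(=O)c4ccc(F)cc4)c3)cc2N1C1CC1` carries a cyclopropyl on the amide-type nitrogen of its shared core. In a functional assay on HeLa cells (Homo sapiens) for antiproliferative activity, read by MTT assay, with a stated time of 72 h (on this read-out higher numbers stand for weaker inhibition and lower numbers for stronger inhibition), compound 2 gives > 40000 nM, which is a limit of the assay and not a number. Compound 3 `COc1ccc(N2C(=O)COc3ccc(-c4cnc5ccccc5c4)cc32)cc1` also sits at a limit, giving > 40000 nM in this assay. Compound 1 `COc1ncc(-c2ccc3c(c2)N(c2ccc(C)cc2)C(=O)CO3)cc1NS(=O)(=O)c1ccc(F)cc1`, which carries another group on the same nitrogen, gives 4650 nM in this assay. Two of the three values are therefore limits, as the limit of > 40000 nM in this assay, at which 2 of the 3 values shown sit, shows, so compound 2 stands at the weak end of what was measured, together with compound 3, with only compound 1 giving a number. Compound 4 `O=C1COc2ccc(-c3cccc(NS(=O)(=O)c4ccc(F)cc4)c3)cc2N1c1ccccc1` differs from compound 2 in one place: phenyl in place of cyclopropyl on an amide-type nitrogen in a ring. Among the compounds with values here, no measured pair shows this exact change, and compound 1 and compound 3 give opposite pictures of what a ring on this nitrogen does. The expected step is an at least 2.0-fold lower number from compound 2 to compound 4 (0.30 log units; that floor lies within the scatter), with a fair chance that only a limit results. For compound 4 the estimate is 20000 nM, in the range 5000 nM to 40000 nM.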

Compound 4, half-maximal inhibitory concentration: 17700 nM
Compound 4: the middle estimate sits 1.1-fold (0.05 log units) above what was measured; the range from low to high includes it.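

In this assay, phenyl in place of cyclopropyl on this amide-type nitrogen gives an at least 2.2-fold lower number from compound 2 to compound 4 (0.35 log units; beyond the scatter). This is the first pair among the compounds shown that differs only at this position, so it is the first direct sign that the group on this nitrogen changes the read-out. The step is only a floor and its full size cannot be read because compound 2 stands at a limit and not at a number: the limit of > 40000 nM in this assay, at which 2 of the 4 values shown sit.

On these data alone, what a longer chain, or a chain ending in an amine, would do on this nitrogen remains open. As far as these compounds go, it is also open whether a methoxy group on the phenyl of compound 4 would lower the number further, with the rest of compound 4 unchanged.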